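Swapping the acetamidophenyl arm for a pyridine

The compounds below may be only part of what the source reports. "The series", "measured", "known", "first", "only" and "open" are said of these compounds alone.

Of the compounds shown here, three have been measured in an assay on cells for inhibition of ubiquitin carboxyl-terminal hydrolase isozyme L5 (Homo sapiens), read by fluorescence, with a stated time of 30 min; a lower number here means a stronger inhibitor, a higher number a weaker inhibitor. Compound 1 `CC(=O)Nc1cccc(-c2cn(Cc3cc(C(=O)O)cc(-c4ccccc4C(=O)O)c3)nn2)c1` gives 96200 nM. Compound 2 `CC(C(=O)O)c1ccc(C(=O)c2cccc(-c3occc3C(=O)O)c2)s1` gives 75700 nM, and compound 3 `CC(C(=O)O)c1ccc(C(=O)c2cccc(-c3ccccc3C(=O)O)c2)s1` gives 89100 nM. All three numbers lie close together: the gap between compound 1 and compound 3, and the gap between compound 1 and compound 2, both fall within the usual scatter of repeated measurements, so compound 1 cannot be set apart from the other two on this evidence.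

For the measured compounds named here, the single one-place step available, a 1.2-fold higher number from compound 2 to compound 3 (0.07 log units; within the scatter), concerns an exchange at a different part of the molecule from the change considered here and is itself within the scatter.

Compound 4 `O=C(O)c1cc(Cn2cc(-c3cccnc3)nn2)cc(-c2ccccc2C(=O)O)c1` differs from compound 1 in one place: pyridin-3-yl in place of 3-acetamidophenyl on an aromatic carbon. Going by the values given here, no measured pair tracks this particular exchange, and the one step that exists, between compound 2 and compound 3, shows no movement beyond the scatter. The expectation therefore rests on compound 1 alone, with a wide margin of uncertainty. Compound 4 is expected to give an estimated 100000 nM in this assay, within a range from 35000 nM to 280000 nM, which corresponds to an expected step of a 1.0-fold higher number from compound 1 to compound 4 (0.02 log units; within the scatter), that is, no change beyond the scatter.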

Compound 4, half-maximal inhibitory concentration: 252000 nM
For compound 4 the middle estimate is 2.5-fold (0.40 log units) below the measured one; the measured number falls inside the stated range.
By their numbers in this assay, from the lowest: compounds 2, 3 and 1 (each within the scatter of the next); then compound 4.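

At this position, an aromatic carbon of a five-membered aromatic ring with 3 nitrogen, the exchange does register in this assay: pyridin-3-yl in place of 3-acetamidophenyl gives a 2.6-fold higher number from compound 1 to compound 4 (0.42 log units; beyond the scatter), the only step among the compounds shown that lies beyond the scatter, though a modest one. This arm is therefore not a silent part of the molecule, and the smaller pyridin-3-yl sits on the weaker side of the pair. The exchange alters several things at once, as the arm goes from 10 heavy atoms to 6 and loses its hydrogen-bond donor while gaining a ring nitrogen, and no measurement here bears on what lies behind the step.

Still open, on these data alone, is whether the step follows the missing acetamide or the ring nitrogen: a plain phenyl group, or an amine in place of the acetamide, would help separate the two. The compounds shown also leave open whether a longer chain or a carboxylic acid on this arm would move the number down rather than up.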